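Cytotoxicity notes on one aryl replacement step

A few compounds are considered here, and "the series" means these few. Any claim that something is new, unique, unknown or untested is made for them only; others in the source may bear on it.

Measured so far:
compound 1 `CCOc1ccc(-c2cc3oc(=O)cc(C)c3cc2OS(=O)(=O)C(F)(F)F)cc1` in a toxicity assay on MT4 cells (Homo sapiens) for cytotoxicity, read by MTT assay, with a stated time of 5 days; on this read-out lower numbers stand for higher toxicity in this test and higher numbers for lower toxicity in this test: >= 27.2 ug/mL, which is a limit of the assay and not a number.
compound 2 `Cc1cc(=O)oc2cc(-c3ccc(C(F)(F)F)cc3)c(OS(=O)(=O)C(F)(F)F)cc12` in this assay: 80.3 ug/mL.

Compound 2 holds the only number shown in this assay; the remaining value is a limit. Compound 3 `Cc1cccc(-c2cc3oc(=O)cc(C)c3cc2OS(=O)(=O)C(F)(F)F)c1` differs from compound 2 by 3-methylphenyl in place of 4-(trifluoromethyl)phenyl on an aromatic carbon. Among the compounds with values here, the single measured step, a step that the limit leaves unreadable from compound 1 to compound 2, cannot be read because of the limit of >= 27.2 ug/mL in this assay, at which 1 of the 2 values shown sits, so no sized precedent for an aryl change exists. Compound 3 is therefore expected close to compound 2, with a 1.3-fold lower number from compound 2 to compound 3 (0.13 log units; within the scatter) expected to stay within the scatter. The estimate for compound 3 is 60 ug/mL, range 20 ug/mL to 160 ug/mL.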

Compound 3, half-maximal cytotoxic concentration: 61.3 ug/mL
Beside the measured number, compound 3's estimate is 1.0-fold (0.01 log units) below it, within the range that was stated.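

In this assay, the aryl group ortho to the ((trifluoromethyl)sulfonyl)oxy group now has its first sized step, a 1.3-fold lower number from compound 2 to compound 3 (0.12 log units; within the scatter). Thus 3-methylphenyl in place of 4-(trifluoromethyl)phenyl, with three fewer heavy atoms and no fluorine, leaves the read-out within the scatter. The steps from compound 1 cannot be read, as its value is a limit: the limit of >= 27.2 ug/mL in this assay, at which 1 of the 3 values shown sits.

This single step does not separate the exchange of trifluoromethyl for methyl from the different place of the substituent on the aryl ring. Going by these compounds, whether an amine or a carboxylic acid on that ring would give a step beyond the scatter remains open.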